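Arylidene phenyl substituents on the shared core: towards compound 4

A few compounds are considered here, and "the series" means these few. Any claim that something is new, unique, unknown or untested is made for them only; others in the source may bear on it.

Measured so far in a functional assay on HT-29 cells (Homo sapiens) for cytotoxicity, read by MTT assay, with a stated time of 72 h; on this read-out higher numbers stand for weaker inhibition and lower numbers for stronger inhibition:
Compound 1 `Cc1ccc(/C=C2\S/C(=N\c3csc(-c4ccc(Cl)cc4)c3)NC2=O)cc1` gives 6400 nM.
Compound 2 `CN(C)c1ccc(/C=C2\S/C(=N\c3csc(-c4ccc(Cl)cc4)c3)NC2=O)cc1` gives 1500 nM.
Compound 3 `O=C1N/C(=N/c2csc(-c3ccc(Cl)cc3)c2)S/C1=C\c1ccc(O)cc1` returns only a limit of the assay, > 50000 nM.

Of the two numbers shown, compound 1 holds the higher one; its nearest neighbour is compound 2, with a 4.3-fold lower number from compound 1 to compound 2 (0.63 log units; beyond the scatter). Compound 3 sits at a limit, (the limit of > 50000 nM in this assay, at which 1 of the 3 values shown sits).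

Compound 4 `COc1ccc(/C=C2\S/C(=N\c3csc(-c4ccc(Cl)cc4)c3)NC2=O)cc1OC` differs from compound 1 by 3,4-dimethoxyphenyl in place of 4-methylphenyl on a double-bonded chain carbon bound to a double-bonded ring carbon. For the measured compounds named here, no measured step puts a methoxy or a second substituent on that ring, so none of the three steps matches the change directly. All of them, however, alter the substituent on the same aromatic carbon: a 4.3-fold lower number from compound 1 to compound 2 (0.63 log units; beyond the scatter), an at least 7.8-fold higher number from compound 1 to compound 3 (0.89 log units; beyond the scatter) and an at least 33-fold higher number from compound 2 to compound 3 (1.52 log units; beyond the scatter). Together they show that the read-out of this assay moves well beyond the scatter in either direction with this substituent, so a change of similar size in compound 4 cannot be excluded. Going by the values given here, the dimethoxyphenyl resembles neither the dimethylamino nor the hydroxy case closely, and no step shows which way it leans.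

For compound 4 a step of a 1.6-fold lower number from compound 1 to compound 4 (0.20 log units; within the scatter) is expected, with a value estimated at 4000 nM (range 1000 nM to 16000 nM).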

Compound 4, half-maximal inhibitory concentration: 10900 nM
Beside the measured number, compound 4's estimate is 2.7-fold (0.44 log units) below it; low and high end bracket the measured number.
By their numbers in this assay, from the lowest: compound 2; then compounds 1 and 4 (each within the scatter of the next). At a limit, above all of these: compound 3.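

In this assay, replacing 4-methylphenyl with 3,4-dimethoxyphenyl on a double-bonded chain carbon bound to a double-bonded ring carbon gives a 1.7-fold higher number from compound 1 to compound 4 (0.23 log units; within the scatter), so this larger group with hydrogen-bond acceptors is accommodated at this position without a change that can be read beyond the scatter. The other two steps place the new compound clearly relative to the earlier substituents, with a 7.3-fold higher number from compound 2 to compound 4 (0.86 log units; beyond the scatter) leaving compound 2 with the lowest number of the four, and an at least 4.5-fold lower number from compound 3 to compound 4 (0.66 log units; beyond the scatter) showing that oxygen substituents on this ring do not in themselves go with the reading of compound 3. The reading of compound 3 is a limit of the assay, so this last step gives only a bound: the limit of > 50000 nM in this assay, at which 1 of the 4 values shown sits.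

The compounds shown leave open whether a single methoxy group on the phenyl ring would read like compound 4, and so which part of the 3,4-dimethoxyphenyl group sets its value. On these data alone, it is also open whether the lower number of compound 2 is specific to dimethylamino or extends to a plain amino group or a pyrrolidine.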